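Adding a Methyl to the Hydroxy Oxygen of Compound 1

The compounds below may be only part of what the source reports. "The series", "measured", "known", "first", "only" and "open" are said of these compounds alone.

Compound 1 `O=C(NCCCNc1cc(-c2cn(-c3ccccc3)nc2-c2cccc(O)c2)ccn1)Nc1ccc(F)cc1` gives 4000 nM
Compound 2 `O=C(NCCCNc1cc(-c2cn(-c3ccccc3)nc2-c2cccc(O)c2)ccn1)Nc1cccc(C(F)(F)F)c1` gives 5290 nM

In a functional assay on SK-MEL-2 cells (Homo sapiens) for antiproliferative activity, read by sulforhodamine B assay, with a stated time of 48 h (on this read-out lower numbers stand for stronger inhibition and higher numbers for weaker inhibition), compound 1 stands at 4000 nM and compound 2 at 5290 nM, so the two sit within the scatter of each other and neither can be ranked ahead. Compound 3 `COc1cccc(-c2nn(-c3ccccc3)cc2-c2ccnc(NCCCNC(=O)Nc3ccc(F)cc3)c2)c1` has not yet been measured. It departs from compound 1 by methyl in place of hydrogen on an oxygen on an aromatic ring, which turns hydroxy into methoxy. For the measured compounds named here, the only measured step is a 1.3-fold higher number from compound 1 to compound 2 (0.12 log units; within the scatter), and it lies within the scatter. That step swaps a different group, so it says nothing directly about the hydroxy group and gives no direction. With so little to go on, the estimated step, a 1.1-fold higher number from compound 1 to compound 3 (0.05 log units; within the scatter), is expected to stay within the scatter in this assay. For compound 3 the expected value is 4500 nM, with an estimated range from 1800 nM to 11000 nM.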

Compound 3, half-maximal inhibitory concentration: 6300 nM
Compound 3: middle estimate off by 1.4-fold (0.15 log units), on the low side; measured number inside the range.
By their numbers in this assay, from the lowest: compounds 1, 2 and 3 (each within the scatter of the next).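

For the compounds shown here, this is the first change made at the hydroxy group itself, and in this assay turning it into methoxy gives a 1.6-fold higher number from compound 1 to compound 3 (0.20 log units; within the scatter) and so leaves compound 1 and compound 3 unranked. The hydrogen on that oxygen can therefore be replaced by a methyl with no change that can be told apart from the ordinary spread of repeat measurements. No measurement at hand gives a reason for this result or tells what the group does in the cells.

Still open, going by these compounds, is whether an ethyl on that oxygen, or an amine or a carboxylic acid in place of the hydroxy group, would move the number beyond that spread. Also open, on these data alone, is whether methoxy would read the same alongside the 3-(trifluoromethyl)phenyl group of compound 2.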